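The source may hold more compounds than are shown below. What is called first, only, known or untested is meant among the compounds shown, and "the series" means these compounds.

Working notes on the series. In a functional assay on FM3A cells (Mus musculus) for antiproliferative activity (a higher number here means a weaker inhibitor, a lower number a stronger inhibitor), compound 1 (`COc1cc(C(=O)c2sc(-c3ccncc3)cc2N)cc(OC)c1OC`) gives 150 nM and compound 2 (`COc1cc(C(=O)c2sc(-c3ccccc3Cl)cc2N)cc(OC)c1OC`) gives 34 nM as the lower of the two numbers. For the measured compounds named here, compound 2 therefore stands lowest so far, although only two numbers are available. The next compound is compound 3 (`COc1cc(C(=O)c2sc(-c3ccc(Cl)c(Cl)c3)cc2N)cc(OC)c1OC`), which has not yet been measured. The change is 3,4-dichlorophenyl in place of 2-chlorophenyl on an aromatic carbon, next to the ring sulfur (3,4-dichlorophenyl in place of 2-chlorophenyl on an aromatic carbon). Going by the values given here, only one measured step exists (a 4.4-fold lower number from compound 1 to compound 2 (0.64 log units; beyond the scatter)). It is modest, lies beyond the scatter and falls at the same carbon, but it replaces pyridin-4-yl with 2-chlorophenyl. It bears on the new change only indirectly, since both compound 2 and compound 3 carry a chlorinated phenyl. The data hold no comparison between chlorine patterns, so neither direction is favoured with any confidence. The expected move (a 1.2-fold higher number from compound 2 to compound 3 (0.07 log units; within the scatter)) is small and is estimated to stay within the scatter. In this assay compound 3 is estimated at 40 nM (expected range 12 nM to 130 nM).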

Compound 3, half-maximal inhibitory concentration: 400 nM
Compound 3: middle estimate off by 10-fold (1.00 log units), on the low side; measured number outside the range, above it.
By their numbers in this assay, from the lowest: compound 2; then compound 1; then compound 3.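

In this assay, for the compounds shown here, the chlorine pattern on the phenyl group at this carbon, next to the ring sulfur, matters far more than the earlier compounds could show: moving to 3,4-dichlorophenyl from 2-chlorophenyl gives a large step (a 12-fold higher number from compound 2 to compound 3 (1.07 log units; beyond the scatter)). A chlorinated phenyl at this carbon therefore does not by itself give the lower number, since compound 2 stands below the pyridin-4-yl of compound 1 while compound 3 stands above it (a 2.7-fold higher number from compound 1 to compound 3 (0.43 log units; beyond the scatter)), and the order of the groups here depends on which chlorinated phenyl is present. No measurement is available that accounts for the size of this step.

Open, on these data alone, is whether the higher number of compound 3 follows the second chlorine or the places of the chlorines, as this step changes both at once, and a single-chlorine group such as 4-chlorophenyl would separate the two. Also open, as far as these compounds go, is how an unsubstituted phenyl, or a phenyl carrying a methoxy group or an amine, would stand against compound 2 at this carbon.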